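This account rests on a few compounds, and the source may have more. Where it says the series, first, only, none or still open, it means among the compounds named here.

The measured compounds:
compound 1, `CCNS(=O)(=O)c1ccc2c(c1)C(n1ccccc1=O)=CC(C)(C)O2`; in a functional assay on the whole organism (trachea) with Rattus norvegicus as the target (a lower number here means a smaller maximal response, a higher number a larger maximal response), compound 1 reaches 87%
compound 2, `CC1(C)C=C(n2ccccc2=O)c2cc(S(=O)(=O)NCc3ccccc3)ccc2O1`; in this assay compound 2 reaches 77.5%
compound 3, `CC1(C)C=C(n2ccccc2=O)c2cc(S(=O)(=O)Nc3ccc([N+](=O)[O-])cc3)ccc2O1`; in this assay compound 3 reaches 75.6%

Compound 3 has the lowest number of the three. Its distance from compound 2 is small, a number 1.9 percentage points lower from compound 2 to compound 3 (within the scatter), while its distance from compound 1 is larger, a number 11.4 percentage points lower from compound 1 to compound 3 (beyond the scatter), so compound 3 is set apart only from compound 1.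

Compound 4, `CC1(C)C=C(n2ccccc2=O)c2cc(S(=O)(=O)Oc3ccccc3)ccc2O1`, differs from compound 3 in one place: phenoxy in place of (4-nitrophenyl)amino on a sulfonyl sulfur. The measured steps that come nearest all exchange the group on the sulfonamide nitrogen: a number 9.5 percentage points lower from compound 1 to compound 2 (within the scatter), a number 11.4 percentage points lower from compound 1 to compound 3 (beyond the scatter) and a number 1.9 percentage points lower from compound 2 to compound 3 (within the scatter). Two of these stay within the scatter and one is modest. Going by the values given here, none of them replaces the whole (4-nitrophenyl)amino with a group joined through oxygen, so the change to compound 4 is of a kind no measured pair covers. Given that the exchanges seen so far moved the maximal response little, a step within the scatter is expected, a number 1.6 percentage points lower from compound 3 to compound 4 (within the scatter). Compound 4 is therefore estimated to reach about 74% in this assay, with a range from 58% to 90%.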

Compound 4, largest response reached (Emax), in percent of the reference or control that the assay uses: 86.7%
The estimate for compound 4 lay 12.7 percentage points below the measured number, within the range that was stated.
By their numbers in this assay, from the lowest: compounds 3, 2, 4 and 1 (each within the scatter of the next, the first and the last beyond it).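

In this assay, going by these compounds alone, phenoxy on the sulfonyl sulfur gives a number 11.1 percentage points higher from compound 3 to compound 4 (beyond the scatter), the first step at this place that moves the number up beyond the scatter and the first that replaces the nitrogen-linked group with one joined through oxygen. The other two steps to phenoxy are a number 9.2 percentage points higher from compound 2 to compound 4 (within the scatter) and a number 0.3 percentage points lower from compound 1 to compound 4 (within the scatter), so compound 4 is set apart from neither compound 2 nor compound 1, and carrying a six-membered aromatic ring on this sulfur does not by itself place a compound apart from the ethylamino compound 1, although compound 3, which also carries such a ring, is set apart from it. Nothing shown here gives a reason for the difference between compound 3 and compound 4.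

The step from compound 3 to compound 4 changes both the linking atom and the nitro group, so it cannot say which of the two goes with the higher number; plain phenylamino or 4-nitrophenoxy on the same sulfur would separate them. As far as these compounds go, whether a non-aromatic group joined through oxygen, such as ethoxy, behaves like phenoxy also stays open.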